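This account rests on a few compounds, and the source may have more. Where it says the series, first, only, none or still open, it means among the compounds named here.

Measured in a functional assay on A549 cells (Homo sapiens) for antiproliferative activity, read by MTT assay, with a stated time of 48 h; a lower number here means a stronger inhibitor, a higher number a weaker inhibitor:
- compound 1 `Cn1cc(-c2cnc3ccnc(N)c3c2)cn1`: 33400 nM
- compound 2 `COc1ccc(C(=O)Nc2ccc3ncc(-c4cnn(C)c4)cc3n2)cc1`: 6400 nM
- compound 3 `CC(=O)Nc1nccc2ncc(-c3cnn(C)c3)cc12`: > 50000 nM

The value of compound 3 is a limit of the assay and not a number. Compound 3 therefore stands only at the limit of > 50000 nM in this assay, at which 1 of the 3 values shown sits.

Compound 4 `Cn1cc(-c2cnc3ccnc(NC(=O)C4CC4)c3c2)cn1` is compound 3 with cyclopropyl in place of methyl on a carbonyl carbon, the acetyl becoming cyclopropylcarbonyl: cyclopropyl in place of methyl on a carbonyl carbon.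

Going by the values given here, one measured step bears on this change, the placing of acetyl in place of hydrogen on a nitrogen on an aromatic ring, which gave an at least 1.4-fold higher number from compound 1 to compound 3 (0.17 log units; that floor lies within the scatter). That step is only a floor, and it lies within the scatter. Among the compounds with values here, compound 2 differs from compound 3 in more than one place, so it gives no step to carry over.

In this assay only a small shift is therefore expected, towards a lower number if any, and possibly none beyond the scatter. The expected step is an at least 1.3-fold lower number from compound 3 to compound 4 (0.11 log units; that floor lies within the scatter). Compound 4 is estimated at 38000 nM, with an expected range of 15000 nM to 50000 nM.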

Compound 4, half-maximal inhibitory concentration: > 50000 nM
Compound 4: no number, only a limit; the forecaster's own chance of this, stated with the estimate: 50%; at least 1.3-fold (0.11 log units) between middle value and limit.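

In this assay, compound 4 gives > 50000 nM, which is a limit of the assay and not a number, and it now shares that limit with compound 3: the limit of > 50000 nM in this assay, at which 2 of the 4 values shown sit. The change from methyl to cyclopropyl on the carbonyl carbon cannot be read, with a limit on both sides of the step. Cyclopropylcarbonyl in place of hydrogen on the nitrogen gives an at least 1.4-fold higher number from compound 1 to compound 4 (0.17 log units; that floor lies within the scatter), so with either acyl group, acetyl or cyclopropylcarbonyl, the number does not come down from that of compound 1.

On these data alone, how far compound 3 and compound 4 lie beyond the limit stays open. Also open, as far as these compounds go, is whether a longer chain, an amine or a carboxylic acid on this carbonyl carbon would bring a number within the range of this assay.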